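The source may report more compounds than this note shows. Statements on the series, on what has been measured and on what is new or still open speak of the compounds shown alone.

Measured so far:
compound 1, `COc1cc(C)cc(-c2c(-c3ccnc(-c4ccc(N(C)C)cc4)c3)cnn2CC#N)c1`, 40%
compound 2, `Cc1cc(O)cc(-c2nn(CC#N)cc2-c2ccnc(-c3ccc(N(C)C)cc3)c2)c1`, 80%

In a functional assay on A498 cells (Homo sapiens) for cytotoxicity, read by sulforhodamine B assay, with a stated time of 48 h, tested at 0.01 uM (a lower number here means a stronger effect, a higher number a weaker effect of the compound at the concentration tested), compound 1 gives 40%, the lower of the two numbers and therefore the stronger effect, while compound 2 gives 80%, a gap beyond the usual scatter. Compound 3, `COc1cc(C)cc(-c2c(-c3ccnc(-c4ccc(C(C)=O)cc4)c3)cnn2CC#N)c1`, has not been measured yet. It differs from compound 1 in one place: acetyl in place of dimethylamino on an aromatic carbon. Among the compounds with values here, no measured pair shows this change, so the step is only expected: a moderate rise toward a weaker effect, a number 18 percentage points higher from compound 1 to compound 3 (beyond the scatter). Compound 3 is estimated at 58%, with a likely range from 32% to 85%.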

Compound 3, a percentage reported as activity, at one concentration (the size of the read-out at that concentration, not a potency): 77%
Compound 3: middle estimate off by 19 percentage points, on the low side, within the range that was stated.
By their numbers in this assay, from the lowest: compound 1; then compounds 3 and 2 (each within the scatter of the next).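

Placing acetyl where dimethylamino stood on this aromatic carbon, para to a large group, clearly weakens the effect in this assay, with a number 37 percentage points higher from compound 1 to compound 3 (beyond the scatter). The effect therefore depends on which group sits here, even though these two groups have the same number of heavy atoms and hydrogen-bond acceptors and neither carries a net charge. Nothing available explains this difference. The compounds shown leave open where a primary amine or a carboxylic acid at this position would fall. They also leave open whether the step would hold at other concentrations.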